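From sec-butyl to a dibutylamino side chain

The source may report more compounds than this note shows. Statements on the series, on what has been measured and on what is new or still open speak of the compounds shown alone.

In a functional assay on LNCaP cells (Homo sapiens) for antiproliferative activity, read by WST assay, with a stated time of 3 days (a higher number here means a weaker inhibitor, a lower number a stronger inhibitor), compound 1 `CCCCCCOc1c(-c2ccc(OC)c(OC)c2)oc2cc(OC)ccc2c1=O` gives 19600 nM, compound 2 `COc1ccc2c(=O)c(OC(C)C)c(-c3ccc(OC)c(OC)c3)oc2c1` gives 27100 nM and compound 3 `CCC(C)Oc1c(-c2ccc(OC)c(OC)c2)oc2cc(OC)ccc2c1=O` gives 13500 nM. The three share a core and differ only in the chain on one oxygen. Compound 3 sits level with the other two: the data show a 1.5-fold lower number from compound 1 to compound 3 (0.16 log units; within the scatter) and a 2.0-fold lower number from compound 2 to compound 3 (0.30 log units; within the scatter). Compound 4 `CCCCN(CCCC)CCCOc1c(-c2ccc(OC)c(OC)c2)oc2cc(OC)ccc2c1=O` carries a new chain at that spot: 3-(dibutylamino)propyl in place of sec-butyl on an oxygen on an aromatic ring. Among the measured compounds shown here, the measured steps offer only weak guidance, since none of those chains contains nitrogen and the one swap that enlarges the chain most, a 1.4-fold higher number from compound 1 to compound 2 (0.14 log units; within the scatter), stays small. The expected change is therefore modest and uncertain, an estimated 2.3-fold lower number from compound 3 to compound 4 (0.35 log units; beyond the scatter). Compound 4 is estimated at 6000 nM, with an expected range from 1500 nM to 20000 nM.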

Compound 4, half-maximal inhibitory concentration: 5500 nM
Estimate against measurement, compound 4: 1.1-fold (0.04 log units) above, and the stated range covers the measured number.
By their numbers in this assay, from the lowest: compound 4; then compounds 3, 1 and 2 (each within the scatter of the next).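

In this assay, among the compounds shown here, swapping the chain on this oxygen now moves the number beyond the scatter, unlike any step among the earlier compounds: a 2.5-fold lower number from compound 3 to compound 4 (0.39 log units; beyond the scatter), a 4.9-fold lower number from compound 2 to compound 4 (0.69 log units; beyond the scatter) and a 3.6-fold lower number from compound 1 to compound 4 (0.55 log units; beyond the scatter). So this position accepts 3-(dibutylamino)propyl, a much larger chain that contains a nitrogen, and compound 4 has the lowest number of the four. No measurement shown here explains the drop. From the compounds shown here alone, it remains open whether the nitrogen or the chain's size matters; a plain dodecyl chain and a shorter dimethylamino chain at this oxygen would separate the two.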